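Methyl removal on the nitrogen-bearing ring: compound 2 to compound 4

The source may report more compounds than this note shows. Statements on the series, on what has been measured and on what is new or still open speak of the compounds shown alone.

Measured so far:
compound 1, `C=C1CC(Cn2cc(C)c(=O)[nH]c2=O)(c2ccc(-c3ccccc3)cc2)OC1=O`: 3720 nM
compound 2, `C=C1CC(Cn2cc(C)c(=O)[nH]c2=O)(c2ccc(F)cc2)OC1=O`: 3550 nM
compound 3, `C=C1CC(Cn2ccc(=O)[nH]c2=O)(c2ccc(-c3ccccc3)cc2)OC1=O`: 1580 nM

The three compounds were examined in a functional assay on Malme-3M cells (Homo sapiens) for inhibition; a higher number here means a weaker inhibitor of growth, a lower number a stronger inhibitor of growth. Compound 2 sits close to compound 1, the difference being a 1.0-fold lower number from compound 1 to compound 2 (0.02 log units; within the scatter), so the two cannot be told apart; compound 3 stands apart from both, beyond the scatter.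

Compound 4, `C=C1CC(Cn2ccc(=O)[nH]c2=O)(c2ccc(F)cc2)OC1=O`, has not yet been measured in this assay. It differs from compound 2 in one place: hydrogen in place of methyl on an aromatic carbon. The same change has been made once before, from compound 1 to compound 3, where it gave a 2.4-fold lower number from compound 1 to compound 3 (0.37 log units; beyond the scatter). That single precedent bears directly on the present step, since the two pairs share the same core and differ only in the group on the other aromatic ring.

It is therefore expected that compound 4 shows a lower number than compound 2, by about a 2.4-fold lower number from compound 2 to compound 4 (0.37 log units; beyond the scatter). The estimate for compound 4 in this assay is 1500 nM, with a range from 800 nM to 3000 nM.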

Compound 4, concentration for 50% growth inhibition: 7590 nM
The estimate for compound 4 lay 5.1-fold (0.70 log units) below the measured number; measured number above the stated range.
By their numbers in this assay, from the lowest: compound 3; then compounds 2 and 1 (each within the scatter of the next); then compound 4.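

In this assay, replacing the methyl with hydrogen has no single direction on this ring position, since it gives a 2.1-fold higher number from compound 2 to compound 4 (0.33 log units; beyond the scatter) when fluoro is on the other aromatic ring, opposite in sign to the earlier step with phenyl there: the same change on two cores in this assay, a 2.4-fold lower number (0.37 log units; beyond the scatter) from compound 1 to compound 3 and a 2.1-fold higher number (0.33 log units; beyond the scatter) from compound 2 to compound 4, 5.0-fold (0.70 log units) apart, beyond the scatter of two such steps. The change of phenyl to fluoro, which made no readable difference with the methyl present, gives a 4.8-fold higher number from compound 3 to compound 4 (0.68 log units; beyond the scatter) once the methyl is gone: the same change on two cores in this assay, a 1.0-fold lower number (0.02 log units; within the scatter) from compound 1 to compound 2 and a 4.8-fold higher number (0.68 log units; beyond the scatter) from compound 3 to compound 4, 5.0-fold (0.70 log units) apart, beyond the scatter of two such steps. The two places therefore do not act independently in this set, and the effect of the methyl can be read only together with the group on the other aromatic ring.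

From the compounds shown here alone, each change rests on just two pairs, so it remains open whether this reversal extends to other groups in place of fluoro, such as chloro or methoxy. Going by these compounds, whether ethyl in place of the methyl would follow either trend also remains open.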